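This account rests on a few compounds, and the source may have more. Where it says the series, first, only, none or still open, it means among the compounds named here.

Working notes on the series. Of the compounds shown here, three carry a number so far, all from a functional assay on the whole organism (strain NMRI) with Mus musculus as the target, with a stated time of 4 h; a lower number here means that less compound is needed, a higher number that more compound is needed for the effect. Compound 1 `Cc1ccc(-c2nc3ccc(Br)cn3c2/C=N/OCc2cn(Cc3ccc([N+](=O)[O-])cc3)nn2)cc1` gives 20 mg/kg. Compound 2 `Cc1cccn2c(/C=N/O)c(-c3ccc(F)cc3)nc12` gives 40 mg/kg in this assay, and compound 3 `Cc1ccc(Cn2cc(CO/N=C/c3c(-c4ccc(F)cc4)nc4c(C)cccn34)nn2)cc1` gives 40 mg/kg. Compound 1 holds the lowest of the three numbers, but its gaps to compound 2 and to compound 3 both fall inside the usual scatter of repeated measurements, so the three compounds cannot be separated on these data. Within the data shown here, no pair among them differs in one place only, so no single-change step can be read from the measured set.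

The next compound, compound 4 `Cc1ccc(Cn2cc(CO/N=C/c3c(-c4ccc(C)cc4)nc4ccc(Br)cn34)nn2)cc1`, differs from compound 1 at one place: methyl in place of nitro on an aromatic carbon. Compound 3 already carries a 4-methylbenzyl group on its triazole and sits within the scatter of compound 1, which is the only hint available for this change. In this assay the step is therefore expected to stay within the scatter, with no direction favoured, no change at the digits printed from compound 1 to compound 4 (within the scatter). Compound 4 is estimated at 20 mg/kg, with a range from 10 mg/kg to 40 mg/kg, pending the measurement.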

Compound 4, minimum effective dose: 100 mg/kg
For compound 4 the middle estimate is 5.0-fold (0.70 log units) below the measured one; the measured number lies above the stated range.
By their numbers in this assay, from the lowest: compounds 1, 2 and 3 (each within the scatter of the next); then compound 4.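

The change from 4-nitrobenzyl to 4-methylbenzyl gives a 5.0-fold higher number from compound 1 to compound 4 (0.70 log units; beyond the scatter) in this assay, so on the core of compound 1 the outcome depends on what sits on this aromatic carbon, para to a large group. Among these compounds, the earlier compounds offered no single-change step and no gap beyond the scatter, so this pair is the first sign that one substituent can separate two compounds, with the nitro compound needing less for the effect. Nothing available on these compounds speaks to the reason for the step.

A single pair cannot show whether the nitro group favours the effect or the methyl group opposes it, and a plain benzyl, a 4-chlorobenzyl, a 4-cyanobenzyl or a 4-aminobenzyl on the same core would help to separate these two readings. From the compounds shown here alone, it also remains open whether the step carries over to other cores, such as that of compound 3, where a 4-nitrobenzyl group would test the same change.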